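Demethylation on a Quinolinone Core Where Every Value Is a Limit

The source may report more compounds than this note shows. Statements on the series, on what has been measured and on what is new or still open speak of the compounds shown alone.

The study follows three measured compounds and one that is still to be tested, all in a functional assay on L1210 cells (Mus musculus) for antiproliferative activity; a higher number here means a weaker inhibitor, a lower number a stronger inhibitor. Compound 1, with the structure `COc1cc2c(c(O)c1OC)c(=O)ccn2C`, gives in this assay only a limit of > 40000 nM. Compound 2, built as `COc1cc2c(c(OC)c1OC)c(=O)ccn2C`, also returns a limit of > 40000 nM. Compound 3, with the structure `COc1cc(C(F)(F)F)cc2nccc(O)c12`, likewise sits at a limit of > 40000 nM. The difference between compound 2 and compound 1 is hydrogen in place of methyl on an oxygen on an aromatic ring, and the step it made, a step that the two limits leave unreadable from compound 2 to compound 1, cannot be read because both ends rest on (the limit of > 40000 nM in this assay, at which 3 of the 3 values shown sit). The difference between the core of compound 3 and the core of compound 2 is not broken down here.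

Compound 4, drawn as `Oc1ccnc2cc(C(F)(F)F)cc(O)c12`, carries the same change against compound 3, namely (hydrogen in place of methyl on an oxygen on an aromatic ring). For this assay the step that the limit leaves unreadable from compound 3 to compound 4 is expected to be small or unreadable, since the earlier change left both partners at the limit of > 40000 nM in this assay, at which 3 of the 3 values shown sit. Compound 4 is therefore estimated at 60000 nM, in a range from 15000 nM to 200000 nM, most likely reported again as a limit.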

Compound 4, half-maximal inhibitory concentration: > 40000 nM
Compound 4 ended at the assay's limit; the forecaster's own chance of this, stated with the estimate: 80%; the middle value does not contradict the limit.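

No step can be read from compound 3 to compound 4 in this assay because both compounds rest on a limit and not on a number: (the limit of > 40000 nM in this assay, at which 4 of the 4 values shown sit). The compounds shown leave open whether methoxy to hydroxy changes anything, and whether in this assay any compound on these cores gives a readable value at all.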